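A few compounds are considered here, and "the series" means these few. Any claim that something is new, unique, unknown or untested is made for them only; others in the source may bear on it.

Compound 1 `COC(=O)[C@@]1(C)CCC=C2[C@@H]1CC[C@@H](C)[C@]2(C)Cc1c[nH]c2ccc(Br)cc12`, compound 2 `COC(=O)[C@@]1(C)CCC=C2[C@@H]1CC[C@@H](C)[C@]2(C)Cc1c[nH]c2ccc(Cl)cc12` and compound 3 `COC(=O)[C@@]1(C)CCC=C2[C@@H]1CC[C@@H](C)[C@]2(C)Cc1c[nH]c2c(Br)cccc12` share one core and differ only in the halogen and where it sits. In a functional assay on T47D cells (Homo sapiens) for inhibition, read by sulforhodamine B assay, with a stated time of 48 h (a lower number here means a stronger inhibitor of growth, a higher number a weaker inhibitor of growth), compound 1 gives 16000 nM and compound 2 gives 17000 nM; the change between them, (chloro in place of bromo on an aromatic carbon), gave a 1.1-fold higher number from compound 1 to compound 2 (0.03 log units; within the scatter). Compound 3 gives 24000 nM in this assay; the difference between its core and that of compound 1 is not broken down here. Compound 4 `COC(=O)[C@@]1(C)CCC=C2[C@@H]1CC[C@@H](C)[C@]2(C)Cc1c[nH]c2c(Cl)cccc12` is not yet measured. It arises from compound 3 by chloro in place of bromo on an aromatic carbon, the same kind of change as from compound 1 to compound 2, although there the halogen sat meta to a fused ring and para to a fused ring, while here it sits ortho to a fused ring and meta to a fused ring. A step of a 1.0-fold higher number from compound 3 to compound 4 (0.02 log units; within the scatter) is expected in this assay because a 1.1-fold higher number from compound 1 to compound 2 (0.03 log units; within the scatter) was small. Compound 4 is therefore estimated at 25000 nM, between 12000 nM and 50000 nM.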

Compound 4, concentration for 50% growth inhibition: 24000 nM
Compound 4: the middle estimate sits 1.0-fold (0.02 log units) above what was measured, within the range that was stated.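

In this assay, chloro in place of bromo on an aromatic carbon gave no change at the digits printed from compound 3 to compound 4 (within the scatter), and the same change on the other core gave a matching result: the same change on two cores in this assay, a 1.1-fold higher number (0.03 log units; within the scatter) from compound 1 to compound 2 and no change at the digits printed (within the scatter) from compound 3 to compound 4, 1.1-fold (0.03 log units) apart, within the scatter of two such steps

So across these two pairs, this exchange of halogens carried from one core to the other without a step beyond the scatter. This does not explain why, and it does not show that any other change would carry over in the same way.

Going by these compounds, all four compounds carry bromo or chloro, so what a plain hydrogen, a methoxy group or an amine would do on that ring remains open. The methyl ester also stays the same throughout, leaving open what a carboxylic acid or an amide there would give.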